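Swapping Acetyl for Benzoyl on a Weak Cytotoxic Amide

The source may hold more compounds than are shown below. What is called first, only, known or untested is meant among the compounds shown, and "the series" means these compounds.

Compound 1 `CC(=O)N1c2ccccc2CCC1C(=O)Nc1ccccc1O` gives the highest number of the two compounds measured in a functional assay on NUGC-3 cells (Homo sapiens) for cytotoxicity, read by sulforhodamine B assay, with a stated time of 72 h; on this read-out lower numbers stand for stronger inhibition of growth and higher numbers for weaker inhibition of growth: compound 1 shows 49700 nM, while compound 2 `CCCC(=O)N1c2ccccc2CCC1C(=O)Nc1cc(C(F)(F)F)cc(C(F)(F)F)c1` shows 14400 nM. Compound 3 `O=C(Nc1ccccc1O)C1CCc2ccccc2N1C(=O)c1ccccc1` differs from compound 1 in one place, (phenyl in place of methyl on a carbonyl carbon). Among the compounds with values here, no measured pair isolates this change, so its direction is uncertain. A modest gain in growth inhibition is expected, with the step of a 2.0-fold lower number from compound 1 to compound 3 (0.30 log units; within the scatter) probably lying near the edge of the scatter. Compound 3 is therefore estimated at 25000 nM, with a range from 8000 nM to 80000 nM.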

Compound 3, concentration for 50% growth inhibition: 3780 nM
For compound 3 the middle estimate is 6.6-fold (0.82 log units) above the measured one; measured number outside the range, below it.
By their numbers in this assay, from the lowest: compound 3; then compound 2; then compound 1.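

On the carbonyl carbon bonded to the amide-type nitrogen in a ring, phenyl in place of methyl gives a 13-fold lower number from compound 1 to compound 3 (1.12 log units; beyond the scatter) in this assay. Compounds 1 and 2 differ in more than one place, so they could not show that this position alone, through the change from acetyl to benzoyl, can shift growth inhibition this far. Nothing measured here explains the gain.

From the compounds shown here alone, whether a cyclohexyl ring, a pyridine ring or a longer chain on this carbonyl carbon would give a similar step stays open. So does whether benzoyl brings the same gain with the amide partner of compound 2.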